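The source may report more compounds than this note shows. Statements on the series, on what has been measured and on what is new or still open speak of the compounds shown alone.

Measured compounds:
- compound 1, `CC(C)[C@@H](NC(=O)/C=C/c1ccncc1-c1ccc2ccccc2c1)C(=O)O`, "not determined" (no result reported)
- compound 2, `COC1CN(C(=O)/C=C/c2ccncc2-c2ccc3ccccc3c2)C1`, > 30000 nM
- compound 3, `CNC(=O)CCc1ccncc1-c1ccc2ccccc2c1`, 19300 nM

Three compounds share a common core; two of them have been tested in a functional assay on HCT-116 cells (Homo sapiens) for inhibition, read by MTT assay, with a stated time of 72 h; on this read-out higher numbers stand for weaker inhibition of growth and lower numbers for stronger inhibition of growth. For compound 1 no result in this assay has been reported. For compound 2 this assay reports only a limit, > 30000 nM, and not a number. For the measured compounds named here, compound 3 gives 19300 nM in this assay, which is the only actual number among the three, so it cannot be ranked against anything else here.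

The next compound, compound 4, `COC(=O)/C=C/c1ccncc1-c1ccc2ccccc2c1`, has not yet been tested. It differs from compound 3 in one place: 2-(methoxycarbonyl)ethenyl in place of 2-(methylcarbamoyl)ethyl on an aromatic carbon. Going by the values given here, since no pair of measured compounds differs in a single place, there is no measured step to lean on, and the limit of > 30000 nM in this assay, at which 1 of the 3 values shown sits, adds no direction.

Among the compounds with values here, with only one number to go on, compound 4 is expected to sit near compound 3, with a step of a 1.6-fold lower number from compound 3 to compound 4 (0.21 log units; within the scatter) that is small and not clearly beyond the usual scatter, leaning if anything toward stronger inhibition. The estimate for compound 4 in this assay is 12000 nM, with a likely range from 4000 nM to 30000 nM.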

Compound 4, concentration for 50% growth inhibition: 350 nM
For compound 4 the middle estimate is 34-fold (1.54 log units) above the measured one, and the stated range ends above it.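

In this assay, the group on the aromatic carbon opposite the ring nitrogen proves to matter greatly: 2-(methoxycarbonyl)ethenyl in place of 2-(methylcarbamoyl)ethyl gives a 55-fold lower number from compound 3 to compound 4 (1.74 log units; beyond the scatter). On the carbonyl carbon, methoxy in place of 3-methoxyazetidin-1-yl gives an at least 85-fold lower number from compound 2 to compound 4 (1.93 log units; beyond the scatter), a step that rests on a limit for compound 2 and not on a number. Nothing shown gives a cause for either step.

The change from compound 3 to compound 4 alters both the number of double bonds in the chain and the amide end, so the compounds shown cannot tell which of the two carries the effect. A saturated chain ending in the methyl ester, or a chain keeping the double bond and ending in the methyl amide, would separate them, and a carboxylic acid at the chain end would test the ester itself.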